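This account rests on a few compounds, and the source may have more. Where it says the series, first, only, none or still open, it means among the compounds named here.

Compound 1 `COc1ccc(S(=O)(=O)N2CCc3cccc(-c4ccc(C#N)cc4)c32)cc1` carries a 4-cyanophenyl group on the shared core. In a functional assay on KB cells (Homo sapiens) for inhibition, with a stated time of 72 h (on this read-out lower numbers stand for stronger inhibition and higher numbers for weaker inhibition), compound 1 gives 31.1 nM, the lowest of the two numbers recorded so far. Compound 2 `COc1ccc(S(=O)(=O)N2CCc3cccc(-c4c(F)c(F)c(F)c(F)c4F)c32)cc1`, which carries a pentafluorophenyl group instead, gives 4040 nM in this assay, a far higher number than compound 1 and well outside the ordinary scatter, so the two values show a clear gap.

Compound 3 `COc1ccc(-c2cccc3c2N(S(=O)(=O)c2ccc(OC)cc2)CC3)cc1` has not been measured. It differs from compound 1 in one place: methoxy in place of cyano on an aromatic carbon. Within the data shown here, no measured pair with this exact change is available, so the size of the step is uncertain. A modest rise in the number, or none beyond the scatter, seems most likely. The step from compound 1 to compound 3 is expected to be a 1.9-fold higher number from compound 1 to compound 3 (0.29 log units; within the scatter). Compound 3 is estimated at 60 nM, with a range from 10 nM to 400 nM.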

Compound 3, half-maximal inhibitory concentration: 337 nM
Beside the measured number, compound 3's estimate is 5.6-fold (0.75 log units) below it; the range from low to high includes it.
By their numbers in this assay, from the lowest: compound 1; then compound 3; then compound 2.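

Changing one group on the phenyl ring of the shared core is enough to shift the result in this assay: methoxy in place of cyano, para to a large group, gives an 11-fold higher number from compound 1 to compound 3 (1.03 log units; beyond the scatter) and so weaker inhibition. Unlike the earlier comparison of measured compounds, this pair isolates a single change at one position, so the position clearly responds to the group placed there. Cyano and methoxy have the same number of heavy atoms and the same hydrogen-bond acceptor and donor counts, so those counts do not separate them, and no measurement here explains the step.

Still open, as far as these compounds go, is how an amine, a carboxylic acid or a longer chain such as butoxy would behave at this position. A single pair also cannot show whether the same step would appear on a different core.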